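Chloro in Place of Methoxy on Two Related Cores

The source may hold more compounds than are shown below. What is called first, only, known or untested is meant among the compounds shown, and "the series" means these compounds.

Compound 2 `COc1cc(C)c(C(=O)N=C(N)N)cc1S(C)(=O)=O` and compound 1 `Cc1cc(Cl)c(S(C)(=O)=O)cc1C(=O)N=C(N)N` share one core. In a functional assay for inhibition of sodium/hydrogen exchanger (Oryctolagus cuniculus) (a higher number here means a weaker inhibitor, a lower number a stronger inhibitor), compound 2 gives 16 nM, and compound 1 gives 25 nM. The change between them, (chloro in place of methoxy on an aromatic carbon), made a 1.6-fold higher number from compound 2 to compound 1 (0.19 log units; within the scatter). Compound 3 `COc1cc(N2CCC(N)CC2)c(S(C)(=O)=O)cc1C(=O)N=C(N)N` stands on a different core, and how its core differs from that of compound 2 is not broken down here. In this assay compound 3 gives 73 nM, the highest of the three numbers. Compound 4 `CS(=O)(=O)c1cc(C(=O)N=C(N)N)c(Cl)cc1N1CCC(N)CC1` has not yet been measured. Its change from compound 3 is chloro in place of methoxy on an aromatic carbon. This is the same kind of change as the earlier one, not the same: in compound 2 the carbon is ortho to a methylsulfonyl group, meta to a methyl group and para to a group of 6 heavy atoms, whereas in compound 3 it is ortho to a group of 6 heavy atoms, meta to a 4-aminopiperidin-1-yl group and para to a methylsulfonyl group. The earlier same kind of change gave a 1.6-fold higher number from compound 2 to compound 1 (0.19 log units; within the scatter). A step of about a 1.4-fold higher number from compound 3 to compound 4 (0.14 log units; within the scatter) is expected on that ground. For compound 4 the estimate in this assay is 100 nM, between 45 nM and 220 nM.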

Compound 4, half-maximal inhibitory concentration: 20 nM
Estimate against measurement, compound 4: 5.0-fold (0.70 log units) above; measured number below the stated range.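

In this assay, chloro in place of methoxy on the core carrying the 4-aminopiperidin-1-yl group gave a 3.7-fold lower number from compound 3 to compound 4 (0.56 log units; beyond the scatter), which is not what the same kind of change did on the core of compound 2. Set side by side, the two steps differ by more than their scatter: the same change on two cores in this assay, a 1.6-fold higher number (0.19 log units; within the scatter) from compound 2 to compound 1 and a 3.7-fold lower number (0.56 log units; beyond the scatter) from compound 3 to compound 4, 5.7-fold (0.76 log units) apart, beyond the scatter of two such steps. Among the compounds shown here, this shows that neither the size nor the direction of the change carried over from one core to the other in these compounds, but it does not show what lies behind the difference, and with only one pair on each core it gives no general rule for the series.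

The compounds shown leave open whether the result on the core of compound 3 depends on the 4-aminopiperidin-1-yl group, and a simple open-chain amine or a carboxylic acid in that place would test this. They also leave open how a fluoro or a nitrile in place of the chloro would read on either core.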